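The source may hold more compounds than are shown below. What is called first, only, known or untested is meant among the compounds shown, and "the series" means these compounds.

Measured so far in a functional assay on A549 cells (Homo sapiens) for inhibition, read by CCK-8 assay, with a stated time of 48 h; on this read-out lower numbers stand for stronger inhibition and higher numbers for weaker inhibition:

- compound 1 `Cc1ccc(-c2nn(-c3ccccc3)cc2C(=O)NC(=S)Nc2ccc(Cl)cc2)cc1` gives 3170 nM
- compound 2 `COc1ccc(-c2nn(-c3ccccc3)cc2C(=O)NC(=S)Nc2ccc(F)cc2)cc1` gives 1430 nM
- compound 3 `O=C(NC(=S)Nc1ccc(Cl)cc1)c1cn(-c2ccccc2)nc1-c1ccc(F)cc1` gives 2990 nM

Going by the values given here, compound 3 stands second highest of the three numbers; its nearest neighbour is compound 1, and the one step between them, a 1.1-fold lower number from compound 1 to compound 3 (0.03 log units; within the scatter), lies within the scatter. Among the compounds with values here, compound 2 gives the lowest number, but it differs from compound 3 in two places, so its value carries no single-point step.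

Compound 4 `COc1ccc(-c2nn(-c3ccccc3)cc2C(=O)NC(=S)Nc2ccc(Cl)cc2)cc1` is not yet measured. It differs from compound 3 by methoxy in place of fluoro on an aromatic carbon. Within the data shown here, no measured step exchanges fluoro for methoxy at this position, so the only bearing evidence is the fluoro-for-methyl exchange at the same place, which moved nothing beyond the scatter, and the observation that compound 2, the only methoxy compound, gives the lowest number while also differing elsewhere. The expected step of a 1.4-fold lower number from compound 3 to compound 4 (0.15 log units; within the scatter) is therefore small, leaning toward a lower number, and not clearly beyond the scatter. Compound 4 is estimated at 2100 nM, with a range of 900 nM to 4800 nM.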

Compound 4, half-maximal inhibitory concentration: 1310 nM
Estimate against measurement, compound 4: 1.6-fold (0.20 log units) above; measured number inside the range.
By their numbers in this assay, from the lowest: compounds 4 and 2 (each within the scatter of the next); then compounds 3 and 1 (each within the scatter of the next).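

In this assay, going by these compounds alone, the change from 4-fluorophenyl to 4-methoxyphenyl gives a 2.3-fold lower number from compound 3 to compound 4 (0.36 log units; beyond the scatter), the first single-place step at this position that lies beyond the scatter. Within the data shown here, the exchange of methyl for methoxy at the same place agrees, with a 2.4-fold lower number from compound 1 to compound 4 (0.38 log units; beyond the scatter), whereas fluoro and methyl could not be told apart in a 1.1-fold lower number from compound 1 to compound 3 (0.03 log units; within the scatter), so methoxy is the one group of the three that separates here. With methoxy in place, chloro for fluoro on the other halogen-bearing aromatic carbon gives a 1.1-fold lower number from compound 2 to compound 4 (0.04 log units; within the scatter), which is within the scatter.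

Nothing at hand gives a reason for the methoxy step. From the compounds shown here alone, whether a hydroxy, ethoxy or dimethylamino group at this place would lower the number further, match methoxy or lose the step remains open.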